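Swapping a Pyridyl for a Dimethylcarbamoyl Amide

This account rests on a few compounds, and the source may have more. Where it says the series, first, only, none or still open, it means among the compounds named here.

Two compounds sharing one core have been run in an ADME assay on the whole organism (Macaca fascicularis) for pharmacokinetics, read by LC-MS, using cassette dosing, at a dose of 1 mg/kg by the oral route; a lower number here means less compound in the circulation, a higher number more compound in the circulation at the dose given. Compound 1 `CCCCN(c1nc2c(CO)cccc2o1)[C@H](C)c1ccc(-c2ccccc2-c2nnn[nH]2)cc1` gives 20.7 nM. Among the compounds with values here, compound 2 `CCCCN(c1nc2c(-c3ccccn3)cccc2o1)[C@H](C)c1ccc(-c2ccccc2-c2nnn[nH]2)cc1` gives 124 nM, the higher of the two numbers, and the one step on record, a 6.0-fold higher number from compound 1 to compound 2 (0.78 log units; beyond the scatter), is the only guide for what follows. Compound 3 `CCCCN(c1nc2c(C(=O)N(C)C)cccc2o1)[C@H](C)c1ccc(-c2ccccc2-c2nnn[nH]2)cc1` is the next member: dimethylcarbamoyl in place of pyridin-2-yl on an aromatic carbon. Within the data shown here, the one measured step does not cover this exact exchange, since it describes what happened when hydroxymethyl became pyridin-2-yl, not when pyridin-2-yl becomes dimethylcarbamoyl. With the group that accompanied the higher number now leaving, a move back toward the number of compound 1 seems the more likely outcome, though how far is uncertain. Compound 3 is therefore expected to give 50 nM in this assay, within 15 nM to 160 nM, a step of a 2.5-fold lower number from compound 2 to compound 3 (0.39 log units; beyond the scatter) estimated as a modest decrease.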

Compound 3, maximal plasma concentration: 54 nM
The estimate for compound 3 lay 1.1-fold (0.03 log units) below the measured number; the range from low to high includes it.
By their numbers in this assay, from the lowest: compound 1; then compound 3; then compound 2.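

Replacing hydroxymethyl with dimethylcarbamoyl, a group with no ring, still gives a 2.6-fold higher number from compound 1 to compound 3 (0.42 log units; beyond the scatter) in this assay, so a number above that of compound 1 does not require an aromatic ring at this position. Even so, pyridin-2-yl remains the group with the highest number of the three, and moving away from it gives a 2.3-fold lower number from compound 2 to compound 3 (0.36 log units; beyond the scatter), so the amide keeps only part of the rise seen with compound 2. Nothing available here explains why the three groups fall in this order.

Going by these compounds, whether a morpholine amide, a primary amide or a carboxylic acid at this position would give a higher or lower number remains open. So does whether pyridin-3-yl would match pyridin-2-yl, which would show how much the place of the ring nitrogen matters.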